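Hydroxycyclohexyl for hydroxypropyl on a second core

The source may report more compounds than this note shows. Statements on the series, on what has been measured and on what is new or still open speak of the compounds shown alone.

Compound 2 `COc1ccc(Cn2c(-c3ccccc3)c(-c3ccccc3)c3c(=N)n(CCCO)cnc32)cc1` and compound 1 `COc1ccc(Cn2c(-c3ccccc3)c(-c3ccccc3)c3c(=N)n([C@H]4CC[C@H](O)CC4)cnc32)cc1` share one core, whereas compound 3 `Cc1c(C)n(Cc2ccccc2)c2ncn(CCCO)c(=N)c12` and compound 4 `Cc1c(C)n(Cc2ccccc2)c2ncn([C@H]3CC[C@H](O)CC3)c(=N)c12` share another; the difference between the two cores is not broken down here. In an ADME assay on microsomes from liver (Mus musculus, strain CD1) for metabolic stability, read by LC-MS, using NADPH, with a stated time of 60 min (a lower number here means that the compound disappears faster, a higher number that the compound lasts longer), compound 2 gives 0.332 h, and compound 1 gives 2 h. The change that separates them is 4-hydroxycyclohexyl in place of 3-hydroxypropyl on an aromatic nitrogen, and it made the step of a 6.0-fold higher number from compound 2 to compound 1 (0.78 log units; beyond the scatter). On the second core, compound 3 gives 2 h in this assay, level with compound 1 at the digits reported and, alongside compound 1, the highest of the three numbers. Compound 4 is reached from compound 3 by the same change, (4-hydroxycyclohexyl in place of 3-hydroxypropyl on an aromatic nitrogen). Going by the values given here, the step from compound 2 to compound 1 was sizeable, but compound 3 already stands where compound 1 stands, and no compound here shows what lies beyond that figure. The step is therefore expected to be small, no change at the digits printed from compound 3 to compound 4 (within the scatter), because compound 3 already stands at 2 h. Compound 4 is expected to give about 2 h, between 1 h and 4 h.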

Compound 4, half-life: 2 h
Estimate against measurement, compound 4: no gap at the digits printed; the measured number falls inside the stated range.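

On the second core, this assay records no change at the digits printed from compound 3 to compound 4 (within the scatter). Set beside the step on the first core, the same change does not carry over in size: the same change on two cores in this assay, a 6.0-fold higher number (0.78 log units; beyond the scatter) from compound 2 to compound 1 and no change at the digits printed (within the scatter) from compound 3 to compound 4, 6.0-fold (0.78 log units) apart, beyond the scatter of two such steps

This shows that the gain seen on the core of compound 1 cannot be assumed on another core in this series. Going by these compounds alone, with only one pair on each core, however, it does not show which feature of the two cores sets the steps apart, and two pairs give no rule for a third core.

The compounds shown leave open how other groups on that aromatic nitrogen would behave, such as an amine in place of the hydroxyl on the six-membered ring, or a longer chain ending in a hydroxyl. They also leave open whether the other arrangement of the two defined stereocentres of 4-hydroxycyclohexyl would give the same picture on either core.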